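One More Methylene on a Phenylalkyl Hydroxamate Chain

A few compounds are considered here, and "the series" means these few. Any claim that something is new, unique, unknown or untested is made for them only; others in the source may bear on it.

Measured compounds:
compound 1 `CN(O)C(=O)/C=C/C=C/c1ccccc1`, 11800000 nM
compound 2 `O=C(CCCCCc1ccccc1)NO`, 83300000 nM
compound 3 `O=C(CCCCCCc1ccccc1)NO`, 47600000 nM

All three were tested in a functional assay on PC-3 cells (Homo sapiens) for inhibition; on this read-out higher numbers stand for weaker inhibition and lower numbers for stronger inhibition. Compound 3 stands second highest of the three numbers. Going by the values given here, its nearest neighbour is compound 2, and the only measured step that changes a single place is a 1.8-fold lower number from compound 2 to compound 3 (0.24 log units; within the scatter). Among the compounds with values here, the furthest from it is compound 1, whose number is the lowest of the three and lies beyond the scatter from compound 3; no single-place step connects these two, so their values are simply noted side by side.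

The next compound, compound 4 `O=C(CCCCCCCc1ccccc1)NO`, differs from compound 3 by (hydroxycarbamoyl)methyl in place of hydroxycarbamoyl on a saturated chain carbon, six bonds along the chain from an aromatic carbon. Within the data shown here, the one measured step that bears on this change is the same kind of lengthening one bond nearer the ring, a 1.8-fold lower number from compound 2 to compound 3 (0.24 log units; within the scatter), which stayed within the scatter. On that basis the expected step in this assay is small, if anything slightly downward, and could well fall inside the scatter. Compound 4 is therefore estimated at 35000000 nM, with a range from 15000000 nM to 90000000 nM. This estimate for compound 4 amounts to a 1.4-fold lower number from compound 3 to compound 4 (0.13 log units; within the scatter).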

Compound 4, half-maximal inhibitory concentration: 83300000 nM
Beside the measured number, compound 4's estimate is 2.4-fold (0.38 log units) below it; the range from low to high includes it.
By their numbers in this assay, from the lowest: compound 1; then compounds 3, 2 and 4 (each within the scatter of the next).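

In this assay the new result, a 1.8-fold higher number from compound 3 to compound 4 (0.24 log units; within the scatter), gives a second reading of the exchange of hydroxycarbamoyl for (hydroxycarbamoyl)methyl, now six bonds along the chain from an aromatic carbon rather than five. Set against a 1.8-fold lower number from compound 2 to compound 3 (0.24 log units; within the scatter), it shows that neither lengthening leaves the scatter, so the earlier single step cannot be read as the start of a steady drift, and compound 2, compound 3 and compound 4 together show no trend with chain length. Nothing available on these compounds accounts for these numbers beyond the values themselves.

Still open, from the compounds shown here alone, is whether a longer chain than that of compound 4, or an ether oxygen or an amide nitrogen placed within the chain, would produce a step beyond the scatter at this position. Going by these compounds alone, also open is whether a methoxy group or a chlorine on the aromatic ring would move the number, and what separates these compounds from compound 1 at 11800000 nM, which no single-place step connects to them.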